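This account rests on a few compounds, and the source may have more. Where it says the series, first, only, none or still open, it means among the compounds named here.

The series shares one core, carried in three measured compounds: compound 1 `COC(=O)[C@@H]1N=C(SCc2ccccc2)[C@H]2C(=O)N(c3ccccc3)C(=O)[C@H]21`, compound 2 `CCCSC1=N[C@H](C(=O)OC)[C@@H]2C(=O)N(c3ccccc3)C(=O)[C@H]12` and compound 3 `COC(=O)[C@H]1N=C(SC)[C@H]2C(=O)N(c3ccccc3)C(=O)[C@H]21`. In a functional assay for inhibition, tested at 100 uM (on this read-out higher numbers stand for more inhibition at the one concentration tested (going by the name of the read-out) and lower numbers for less inhibition), compound 1 gives 98%, compound 2 gives 86% and compound 3 gives 84%. Compound 3 therefore holds the lowest of the three numbers, though its neighbour compound 2 sits within the scatter of it, and only compound 1 stands beyond the scatter above it. Within the data shown here, the single one-place step among the measured compounds runs a number 2 percentage points lower from compound 2 to compound 3 (within the scatter), a change on the chain bound to the sulfur that left the read-out essentially unmoved.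

Compound 4 `COC(=O)[C@@H]1N=C(SC)[C@H]2C(=O)N(c3ccccc3)C(=O)[C@H]21` is the unmeasured compound. Relative to compound 3 the difference is this: the two compounds have the same atoms and bonds and differ only in configuration as drawn: 1 of 3 stereo elements differ; a stereocentre at a saturated ring carbon is drawn S in compound 3 and R in compound 4. Among the measured compounds shown here, no measured step in this set changes a configuration, so the only guide is the measured step on the sulfur chain, which was small, together with the narrow spread of all three numbers, which run from compound 3 to compound 1 over a modest range. The expected step from compound 3 is therefore a number 1 percentage points higher from compound 3 to compound 4 (within the scatter), which is expected to lie within the scatter. For compound 4 in this assay the estimated value is 85%, with a range from 62% to 98%.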

Compound 4, a percentage reported as inhibition, at one concentration (the size of the read-out at that concentration, not a potency): 93%
The estimate for compound 4 lay 8 percentage points below the measured number, and the stated range covers the measured number.
By their numbers in this assay, from the lowest: compounds 3, 2, 4 and 1 (each within the scatter of the next, the first and the last beyond it).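

Changing the drawn configuration at a saturated ring carbon from S to R, with all atoms and bonds kept, gives in this assay a number 9 percentage points higher from compound 3 to compound 4 (within the scatter), so at the one concentration tested this inversion has no effect that can be told from the usual scatter. The sulfur chain also gains a second reading, now with the ring carbon drawn R: taking the phenyl group off that chain gives a number 5 percentage points lower from compound 1 to compound 4 (within the scatter), and this step, like a number 2 percentage points lower from compound 2 to compound 3 (within the scatter), does not leave the scatter. The first of these readings speaks to configuration at that one stereocentre and to nothing else, resting on a single fact: the fact that compounds 3 and 4 differ only in the configuration as drawn

Going by these compounds, the other two stereo elements remain untested on their own, and a single concentration cannot say whether these compounds differ in potency. Also open, on these data alone, is how the read-out would respond to a carboxylic acid in place of the methyl ester, or to an amine on the phenyl group of the shared core.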